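Morpholine Amide to Methylamide: Expected Clearance in Monkey Microsomes

The source may hold more compounds than are shown below. What is called first, only, known or untested is meant among the compounds shown, and "the series" means these compounds.

Measured compounds:
compound 1 `CC[C@H](C)[C@@H]1C(=O)N[C@H](C2Cc3ccccc3C2)C(=O)N1[C@@H](C(=O)N(C)C)c1ccc(C)nc1C` gives 14 mL.min-1.g-1
compound 2 `CCC(CC)[C@@H]1C(=O)N[C@H](C2Cc3ccccc3C2)C(=O)N1[C@@H](C(=O)N1CCOCC1)c1ccc(C)nc1C` gives 14 mL.min-1.g-1

Both values come from an in vitro ADME assay on microsomes from liver (Macaca fascicularis) for metabolic stability; a lower number here means slower removal, a higher number faster removal of the compound. In this assay compound 2 stands level with compound 1 at the digits shown, the two numbers lying within the usual scatter of each other, so no order can be drawn between them.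

Compound 3 `CCC(CC)[C@@H]1C(=O)N[C@H](C2Cc3ccccc3C2)C(=O)N1[C@@H](C(=O)NC)c1ccc(C)nc1C` has not yet been measured. It differs from compound 2 in one place: methylamino in place of morpholin-4-yl on a carbonyl carbon. Cut one bond further out, the change reads as methylcarbamoyl in place of (morpholin-4-yl)carbonyl.

Going by the values given here, no measured pair shows this difference, so the data give no step for it. With compound 1 and compound 2 both at the same level despite differing amide groups, compound 3 is expected to stay within the scatter, the estimated step being a 1.2-fold lower number from compound 2 to compound 3 (0.07 log units; within the scatter). The expected value for compound 3 in this assay is 12 mL.min-1.g-1, with a range from 6 mL.min-1.g-1 to 25 mL.min-1.g-1.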

Compound 3, intrinsic clearance in microsomes: 31 mL.min-1.g-1
For compound 3 the middle estimate is 2.6-fold (0.41 log units) below the measured one; the whole stated range lies below it.
By their numbers in this assay, from the lowest: compounds 1 and 2 (each within the scatter of the next); then compound 3.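

In this assay, methylamino in place of morpholin-4-yl on a carbonyl carbon gives a 2.2-fold higher number from compound 2 to compound 3 (0.35 log units; beyond the scatter), so the group on this carbonyl carbon does bear on the read-out. Going by these compounds alone, compounds 1 and 2 could not show this, as they differ in more than one place and so give no single-place step. No supporting measurement bears on why the number rises.

The change both removes the six-membered non-aromatic ring and brings in the amide hydrogen, and this single pair cannot tell which of the two goes with the higher number. Where an ethylamino or a piperidin-1-yl group on the same carbonyl carbon would fall in this assay also remains open.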